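A Nitro-Bearing Aniline Joins a Weakly Cytotoxic Series

The source may report more compounds than this note shows. Statements on the series, on what has been measured and on what is new or still open speak of the compounds shown alone.

Of the compounds shown here, three sharing one core have been tested in a functional assay on PC-3 cells (Homo sapiens) for cytotoxicity, read by MTT assay, with a stated time of 72 h; a lower number here means a stronger inhibitor, a higher number a weaker inhibitor. Compound 1 `FC(F)(F)c1ccc(CSc2nc(Nc3ccccc3Cl)c3ccccc3n2)cc1` gives 20400 nM; compound 2 `COc1ccccc1Nc1nc(SCc2ccc(C(F)(F)F)cc2)nc2ccccc12` gives 14100 nM; compound 3 `Cc1ccccc1Nc1nc(SCc2ccc(C(F)(F)F)cc2)nc2ccccc12` gives 36900 nM, the highest of the three numbers. The steps among them are small or modest: a 1.4-fold lower number from compound 1 to compound 2 (0.16 log units; within the scatter), a 1.8-fold higher number from compound 1 to compound 3 (0.26 log units; within the scatter) and a 2.6-fold higher number from compound 2 to compound 3 (0.42 log units; beyond the scatter). Compound 4 `O=[N+]([O-])c1ccc(Nc2nc(SCc3ccc(C(F)(F)F)cc3)nc3ccccc23)cc1` differs from compound 3 by 4-nitrophenyl in place of 2-methylphenyl on a nitrogen on an aromatic ring. Going by the values given here, none of the measured steps brings in a nitrophenyl, so they offer only indirect guidance; all of them, however, show that changing the group on this nitrogen has moved the numbers little. Compound 4 is therefore expected to give about 25000 nM, with a range from 8000 nM to 80000 nM. The expected step is a 1.5-fold lower number from compound 3 to compound 4 (0.17 log units; within the scatter), no more than modest in either direction.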

Compound 4, half-maximal inhibitory concentration: 7900 nM
Estimate against measurement, compound 4: 3.2-fold (0.50 log units) above, and the stated range ends above it.
By their numbers in this assay, from the lowest: compounds 4, 2, 1 and 3 (each within the scatter of the next, the first and the last beyond it).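

In this assay, 4-nitrophenyl in place of 2-methylphenyl on this nitrogen gives a 4.7-fold lower number from compound 3 to compound 4 (0.67 log units; beyond the scatter), so the group here can move the number beyond the scatter. Against the chloro compound the change gives a 2.6-fold lower number from compound 1 to compound 4 (0.41 log units; beyond the scatter), whereas a 1.8-fold lower number from compound 2 to compound 4 (0.25 log units; within the scatter) stays within the scatter. Nothing measured here explains these steps.

The compounds shown leave open whether the nitro group itself or its place on the ring goes with the lower number, as compound 4 differs from the others in both. Going by these compounds, how an amine or a carboxylic acid in place of the nitro group would read also remains open.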